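Replacing a ring hydrogen with a dichlorophenyl group

The source may report more compounds than this note shows. Statements on the series, on what has been measured and on what is new or still open speak of the compounds shown alone.

Measured compounds:
- compound 1 `O=C(CCCCC1CCSS1)NCc1cn(CCCOc2ccc3cc(-c4ccc(Br)cc4)c(=O)oc3c2)nn1`: 39.5%
- compound 2 `O=C(CCCCC1CCSS1)NCc1cn(CCCCCOc2ccc3ccc(=O)oc3c2)nn1`: 46.3%
- compound 3 `Cc1cc(=O)oc2cc(OCCCCCn3cc(CNC(=O)CCCCC4CCSS4)nn3)ccc12`: 45.6%

In a functional assay on PC-12 cells (Rattus norvegicus) for cytotoxicity, read by MTT assay, with stated times of 3 h and 2 h, tested at 0.1 uM (a lower number here means a weaker effect, a higher number a stronger effect of the compound at the concentration tested), compound 2 sits at the top of these three numbers, but its gap to compound 3 a number 0.7 percentage points lower from compound 2 to compound 3 (within the scatter) and its gap to compound 1 both lie within the scatter, so the three are not truly distinguished. Compound 4 `O=C(CCCCC1CCSS1)NCc1cn(CCCCCOc2ccc3cc(-c4ccc(Cl)c(Cl)c4)c(=O)oc3c2)nn1` arises from compound 2 by one change: 3,4-dichlorophenyl in place of hydrogen on an aromatic carbon. Among the measured compounds shown here, no measured step covers the same change; only compound 1 carries an aryl group at that place and also a shorter chain, and its number is close to that of compound 2. With no step beyond the scatter anywhere here, compound 4 is expected to give a number near that of compound 2, with an expected step of a number 3.3 percentage points lower from compound 2 to compound 4 (within the scatter), and an estimate of 43% between 32% and 54%.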

Compound 4, a percentage reported as activity, at one concentration (the size of the read-out at that concentration, not a potency): 39.7%
For compound 4 the middle estimate is 3.3 percentage points above the measured one, within the range that was stated.
By their numbers in this assay, from the lowest: compounds 1, 4, 3 and 2 (each within the scatter of the next).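

In this assay, among the compounds shown here, the step of a number 6.6 percentage points lower from compound 2 to compound 4 (within the scatter) is the first reading of an aryl group at this place with the chain held the same. Compound 1 also carries an aryl group here, but it differs from compound 2 in its chain as well. The step shows that 3,4-dichlorophenyl, with 8 heavy atoms, can replace hydrogen on this aromatic carbon without a change beyond the scatter at this one concentration.

On these data alone, how an unsubstituted phenyl, an amine or a carboxylic acid at this place would read remains open. Nothing available explains this result.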